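From Trifluoromethyl to Fluoro on a Shared Core

This account rests on a few compounds, and the source may have more. Where it says the series, first, only, none or still open, it means among the compounds named here.

Compound 3 `O=[N+]([O-])c1cn2c(n1)OC[C@@H](OCc1nnn(-c3ccc(C(F)(F)F)cc3)n1)C2` is one of three compounds tested in an ADME assay on Vero cells (Chlorocebus sabaeus) for cytotoxicity, with a stated time of 72 h; on this read-out higher numbers stand for weaker inhibition and lower numbers for stronger inhibition. In this assay compound 3 gives > 128000 nM, which is a limit of the assay and not a number. Compound 2 `O=[N+]([O-])c1cn2c(n1)OC[C@@H](OCc1nnn(-c3ccccc3)n1)C2` gives > 128000 nM, likewise a limit. Compound 1 `O=[N+]([O-])c1cn2c(n1)OC[C@@H](OCc1ccc(-c3ccc(F)nc3)s1)C2` gives > 128000 nM, again a limit. In short, (the limit of > 128000 nM in this assay, at which 3 of the 3 values shown sit). Against this background the step that the two limits leave unreadable from compound 2 to compound 3 cannot be read. Compound 4 `O=[N+]([O-])c1cn2c(n1)OC[C@@H](OCc1nnn(-c3ccc(F)cc3)n1)C2` differs from compound 3 by fluoro in place of trifluoromethyl on an aromatic carbon. Among the compounds with values here, the only measured step that bears on this change is the unreadable one from compound 2 to compound 3, so no size can be carried over; with every value at the same limit, no step beyond the scatter is expected in this assay. Compound 4 is therefore expected to sit at the limit as well, with an estimate of 200000 nM and a range from 100000 nM to 500000 nM. The step that the limit leaves unreadable from compound 3 to compound 4 implied by this estimate is expected to be none beyond the scatter.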

Compound 4, half-maximal inhibitory concentration: > 128000 nM
Compound 4 gave a limit, no number; the forecaster's own chance of this, stated with the estimate: 90%; the middle value is on the limit's open side.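

In this assay compound 4 gives > 128000 nM, which is a limit and not a number. No step among compound 2, compound 3 and compound 4 can be read: the limit of > 128000 nM in this assay, at which 4 of the 4 values shown sit.

The compounds shown leave open whether hydrogen, fluoro or trifluoromethyl on the aromatic carbon makes any difference in this assay.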